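Swapping a Nitrile for a Methyl Ester on the Chain

The compounds below may be only part of what the source reports. "The series", "measured", "known", "first", "only" and "open" are said of these compounds alone.

Compound 1 `CCc1cc(C(C)=O)c(O)cc1OCCCCC#N`: 92%
Compound 2 `C=CCc1cc(C(C)=O)c(O)cc1OCCCCCC#N`: 81%
Compound 3 `CCc1cc(C(C)=O)c(O)cc1OCCCC(C)(C)C(=O)O`: 89%

These three were measured in an assay on isolated protein for inhibition of leukotriene B4 receptor 1 (Homo sapiens), tested at 10 uM; a lower number here means less inhibition, a higher number more inhibition at the concentration tested (going by the name of the read-out). Compound 2 gives the lowest of the three numbers: it lies below compound 1 by more than the usual scatter, while compound 3 sits within the scatter of it. Compound 4 `C=CCc1cc(C(C)=O)c(O)cc1OCCCCCC(=O)OC` differs from compound 2 by methoxycarbonyl in place of cyano on a saturated chain carbon, five bonds along the chain from an oxygen on an aromatic ring. Among the measured compounds shown here, the one measured step that resembles this change is a number 3 percentage points lower from compound 1 to compound 3 (within the scatter), where 1-carboxy-1-methylethyl replaced cyanomethyl on a chain of the same kind, and the number barely moved. On that basis the methoxycarbonyl is expected to change the read-out little, with a step of a number 1 percentage points lower from compound 2 to compound 4 (within the scatter). Compound 4 is therefore estimated at 80%, within 65% to 92%.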

Compound 4, a percentage reported as inhibition, at one concentration (the size of the read-out at that concentration, not a potency): 106%
For compound 4 the middle estimate is 26 percentage points below the measured one; measured number above the stated range.
By their numbers in this assay, from the lowest: compounds 2, 3 and 1 (each within the scatter of the next, the first and the last beyond it); then compound 4.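

On this chain, the group at the far end can clearly shift the read-out: methoxycarbonyl in place of cyano gives a number 25 percentage points higher from compound 2 to compound 4 (beyond the scatter) in this assay. The earlier end-group change, a number 3 percentage points lower from compound 1 to compound 3 (within the scatter), gave no sign of a shift this large, though it was made on a different chain and with a different group.

Still open, from the compounds shown here alone, is whether an ethyl ester or a primary amide at the same chain end would keep the higher number, and whether the same swap would do so on the shorter chain of compound 1. Nothing measured here explains the rise.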